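The source may report more compounds than this note shows. Statements on the series, on what has been measured and on what is new or still open speak of the compounds shown alone.

Measured in a functional assay on MCF7 cells (Homo sapiens) for cytotoxicity, read by MTT assay, with a stated time of 96 h; a higher number here means a weaker inhibitor, a lower number a stronger inhibitor:
- Compound 1 `COc1cc(C(=O)c2cn(-c3ccccc3)cc2-c2ccc(Br)cc2)cc(OC)c1OC`: 340 nM
- Compound 2 `COc1cc(C(=O)c2cn(-c3ccccc3)cc2-c2ccccc2[N+](=O)[O-])cc(OC)c1OC`: 49 nM
- Compound 3 `COc1ccc(Br)cc1-c1cn(-c2ccccc2)cc1C(=O)c1cc(OC)c(OC)c(OC)c1`: 2200 nM

Compound 3 has the highest number of the three, which makes it the weakest inhibitor in this small set. Compound 4 `COc1cc(C(=O)c2cn(-c3ccccc3)cc2-c2cc(F)ccc2F)cc(OC)c1OC` has not yet been measured. It carries 2,5-difluorophenyl in place of 5-bromo-2-methoxyphenyl on an aromatic carbon.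

All three measured steps swap the group on this same carbon while the rest of the molecule stays the same. Putting 5-bromo-2-methoxyphenyl in place of 4-bromophenyl gave a 6.5-fold higher number from compound 1 to compound 3 (0.81 log units; beyond the scatter), a modest step. Putting it in place of 2-nitrophenyl gave a 45-fold higher number from compound 2 to compound 3 (1.65 log units; beyond the scatter), a large one. Replacing 4-bromophenyl with 2-nitrophenyl gave a 6.9-fold lower number from compound 1 to compound 2 (0.84 log units; beyond the scatter), also modest. Among the compounds with values here, both other groups therefore give lower numbers than the group of compound 3, but no measured compound carries fluorine, so the size of the change remains uncertain.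

The smaller gap, a 6.5-fold higher number from compound 1 to compound 3 (0.81 log units; beyond the scatter), is the more cautious guide, read in reverse. A modest step to a lower number is therefore expected in this assay. The expected change is a 7.3-fold lower number from compound 3 to compound 4 (0.87 log units; beyond the scatter). Compound 4 is estimated at 300 nM, with an expected range of 60 nM to 1500 nM.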

Compound 4, half-maximal inhibitory concentration: 230 nM
Compound 4: middle estimate off by 1.3-fold (0.12 log units), on the high side, within the range that was stated.
By their numbers in this assay, from the lowest: compound 2; then compounds 4 and 1 (each within the scatter of the next); then compound 3.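

In this assay, putting 2,5-difluorophenyl in place of 5-bromo-2-methoxyphenyl gives a 9.6-fold lower number from compound 3 to compound 4 (0.98 log units; beyond the scatter), so the high number of compound 3 does not follow from simply having groups at the two ring positions named in these substituents, since compound 4 has them too. Its other steps place the new group among the earlier ones: a 1.5-fold lower number from compound 1 to compound 4 (0.17 log units; within the scatter), so 2,5-difluorophenyl and 4-bromophenyl cannot be told apart here, whereas a 4.7-fold higher number from compound 2 to compound 4 (0.67 log units; beyond the scatter) shows that the 2-nitrophenyl compound keeps a clear edge over the difluoro compound. No measurement shown here accounts for these differences between groups.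

Still open, on these data alone, is which part of 5-bromo-2-methoxyphenyl goes with the higher number, a question that 2-methoxyphenyl at this carbon would help to answer, and whether one fluorine, as in 2-fluorophenyl, would match the two in compound 4. As far as these compounds go, it is also open how a 2-aminophenyl group would compare with the 2-nitrophenyl group of compound 2, and whether the order seen here holds when the phenyl group on the ring nitrogen is changed.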